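The source may hold more compounds than are shown below. What is called first, only, known or untested is meant among the compounds shown, and "the series" means these compounds.

Compound 1 `CC(C)(C)[Si](OCCc1ccc(=O)[nH]n1)(c1ccccc1)c1ccccc1`: 56200 nM
Compound 2 `O=c1ccc(CCO)nn1Cc1ccccc1`: limit, > 100000 nM
Compound 3 `Cn1nc(CO)ccc1=O`: limit, > 100000 nM

Within the data shown here, in a functional assay on aorta (Rattus norvegicus) (on this read-out higher numbers stand for weaker inhibition and lower numbers for stronger inhibition), compound 1 gives 56200 nM, the only plain number among the three results, and a weak one. Compound 2 reaches only a limit of the assay, > 100000 nM, so no number is known for it. Compound 3 likewise stands at a limit, > 100000 nM. Among the measured compounds shown here, two of the three results therefore sit at the same limit (the limit of > 100000 nM in this assay, at which 2 of the 3 values shown sit), leaving compound 1 as the single compound with a measured inhibition.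

Compound 4 `Cn1nc(CO[Si](c2ccccc2)(c2ccccc2)C(C)(C)C)ccc1=O` has not been measured. It contains the same atoms as compound 1, joined differently: a group of 8 heavy atoms (5 carbon, 2 nitrogen, 1 oxygen; one six-membered aromatic ring with 2 hetero atoms) in place of a group of 8 heavy atoms (5 carbon, 2 nitrogen, 1 oxygen; one six-membered aromatic ring with 2 hetero atoms), on a saturated chain carbon bound to an oxygen. For the measured compounds named here, no step between measured compounds is known that would show how large such a change tends to be in this assay. What can be said is that compound 4 carries the ring fragment in the arrangement found in compound 3. Compound 3 reaches only a limit, > 100000 nM. The step of a 1.8-fold higher number from compound 1 to compound 4 (0.25 log units; within the scatter) is therefore expected to be a weakening, of a size near the edge of the scatter or somewhat beyond it, with a real chance that only a limit is reported. Compound 4 is expected to give about 100000 nM, within a range from 30000 nM to 300000 nM.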

Compound 4, half-maximal inhibitory concentration: 58400 nM
Compound 4: the middle estimate sits 1.7-fold (0.23 log units) above what was measured; the range from low to high includes it.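

In this assay the exchange of one ring fragment for the other gives a 1.0-fold higher number from compound 1 to compound 4 (0.02 log units; within the scatter), so on a saturated chain carbon bound to an oxygen this rearrangement of the same atoms leaves no readable mark on the inhibition. The fragment that leaves has 1 hydrogen-bond donor and 2 hydrogen-bond acceptors and the one that enters has 0 donors and 3 acceptors, and this difference in the counts comes with no change beyond the scatter. Among these compounds, compound 4 also supplies the first plain number for a compound carrying the ring fragment of compound 3, which shows that this fragment can go with measurable, though weak, inhibition.

Going by these compounds, compound 3 is recorded only as a limit, > 100000 nM, so the step to it cannot be read, and the same holds for any step to a compound at that limit: the limit of > 100000 nM in this assay, at which 2 of the 4 values shown sit. Whether a carboxylic acid or an amine in place of the silyl ether would shift the number at all remains open, and so does the question of how far inhibition in this tissue can be strengthened from this starting point.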